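A few compounds are considered here, and "the series" means these few. Any claim that something is new, unique, unknown or untested is made for them only; others in the source may bear on it.

Measured compounds:
- compound 1 `Nc1ccccc1NC(=O)c1ccc(CSC(=S)N2CCN(c3ccc(F)cc3)CC2)cc1`: 18.8%
- compound 2 `Nc1ccccc1NC(=O)c1ccc(CSC(=S)N2CCN(c3ccccc3F)CC2)cc1`: 33.7%
- compound 3 `Nc1ccccc1NC(=O)c1ccc(CSC(=S)N2CCc3cc(Cl)ccc32)cc1`: 57.7%

All three share the same core and were tested in a functional assay on MGC-803 cells (Homo sapiens) for antiproliferative activity, read by CCK-8 assay, with a stated time of 72 h, tested at 2 uM; a lower number here means a weaker effect, a higher number a stronger effect of the compound at the concentration tested. Compound 2 stands second highest of the three; its nearest neighbour is compound 1, which gives a number lower than compound 2 by a step beyond the scatter, while compound 3 lies furthest away, higher by a step beyond the scatter.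

The next compound, compound 4 `Cc1ccc(N2CCN(C(=S)SCc3ccc(C(=O)Nc4ccccc4N)cc3)CC2)cc1`, is derived from compound 2 by a single exchange: 4-methylphenyl in place of 2-fluorophenyl on an amine nitrogen in a ring. Among the measured compounds shown here, the only measured step that bears on this place is the one between compound 1 and compound 2, where the fluorine on the phenyl ring moved from the 4-position to the 2-position and the read-out rose, a number 14.9 percentage points higher from compound 1 to compound 2 (beyond the scatter). For the measured compounds named here, compound 4 goes the other way, back to a group on the 4-position, though now a methyl rather than a fluorine, so no measured pair shows the methyl itself. Going by the values given here, the expected step is therefore a modest fall in this assay, a number 8.7 percentage points lower from compound 2 to compound 4 (within the scatter), with wide uncertainty because only one step, a number 14.9 percentage points higher from compound 1 to compound 2 (beyond the scatter), informs it. Compound 4 is thus estimated at 25%, within a range from 10% to 45%.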

Compound 4, a percentage reported as inhibition, at one concentration (the size of the read-out at that concentration, not a potency): 33.4%
Estimate against measurement, compound 4: 8.4 percentage points below; the measured number falls inside the stated range.
By their numbers in this assay, from the lowest: compound 1; then compounds 4 and 2 (each within the scatter of the next); then compound 3.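

In this assay, putting 4-methylphenyl in place of 2-fluorophenyl on the amine nitrogen gives a number 0.3 percentage points lower from compound 2 to compound 4 (within the scatter), so this assay does not tell these two groups apart. The more informative comparison keeps the group on the same ring carbon and changes only its identity: methyl in place of fluoro gives a number 14.6 percentage points higher from compound 1 to compound 4 (beyond the scatter), so the number depends on which group is present and not only on where it sits on the phenyl ring. The earlier step from compound 1 to compound 2 could have suggested that a group at the 4-position was unfavourable, but compound 4 goes against that reading, and nothing given here explains the difference between methyl and fluoro.

From the compounds shown here alone, it remains open what an unsubstituted phenyl or 4-chlorophenyl would give on the same nitrogen, and whether 2-methylphenyl would match 2-fluorophenyl as closely as 4-methylphenyl does. Compound 3 differs from the other compounds in more than one place, so these comparisons also leave open which part of its structure accounts for its number.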